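Swapping chloro for methoxy on a nitrofuran amide core

This account rests on a few compounds, and the source may have more. Where it says the series, first, only, none or still open, it means among the compounds named here.

Compound 1 `CN1CCN(c2ccn3c(-c4ccc(NC(=O)c5ccc([N+](=O)[O-])o5)cc4)cnc3c2)CC1` — 1580 nM
Compound 2 `O=C(Nc1ccc(-c2cnc3cc(N4CCC4)ccn23)cc1)c1ccc([N+](=O)[O-])o1` — > 5000 nM
Compound 3 `O=C(Nc1ccc(-c2cnc3cc(Cl)ccn23)cc1)c1ccc([N+](=O)[O-])o1` — 4620 nM

Three compounds share a core and differ only in one group on the bicyclic ring. In a functional assay on MGC-803 cells (Homo sapiens) for antiproliferative activity, read by CCK-8 assay, with a stated time of 72 h (a lower number here means a stronger inhibitor, a higher number a weaker inhibitor), compound 1 gives 1580 nM. Compound 2 reaches only the limit of this assay, > 5000 nM, so its value is a boundary rather than a number (the limit of > 5000 nM in this assay, at which 1 of the 3 values shown sits). Within the data shown here, compound 3 gives 4620 nM in this assay, the highest of the two numbers known, with compound 1 the nearest at a 2.9-fold higher number from compound 1 to compound 3 (0.47 log units; beyond the scatter). Compound 2 and compound 3 differ by an at least 1.0-fold lower number from compound 2 to compound 3 (0.03 log units; that floor lies within the scatter).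

Compound 4 `COc1ccn2c(-c3ccc(NC(=O)c4ccc([N+](=O)[O-])o4)cc3)cnc2c1` is not yet measured. It differs from compound 3 by methoxy in place of chloro on an aromatic carbon. The measured steps at this position show that a large basic ring helped (a 2.9-fold higher number from compound 1 to compound 3 (0.47 log units; beyond the scatter)) while the small azetidine did not, (an at least 3.1-fold higher number from compound 1 to compound 2 (0.50 log units; beyond the scatter)). Methoxy is a small group like chloro, so no step beyond the scatter is expected. Compound 4 is therefore estimated at 4500 nM, with a likely range from 1500 nM to 15000 nM. This corresponds to an expected step of a 1.0-fold lower number from compound 3 to compound 4 (0.01 log units; within the scatter).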

Compound 4, half-maximal inhibitory concentration: 860 nM
Estimate against measurement, compound 4: 5.2-fold (0.72 log units) above, and the stated range ends above it.
By their numbers in this assay, from the lowest: compounds 4 and 1 (each within the scatter of the next); then compound 3. At a limit, above all of these: compound 2.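

At this position, opposite the ring nitrogen, methoxy and chloro are not interchangeable in this assay: the exchange gives a 5.4-fold lower number from compound 3 to compound 4 (0.73 log units; beyond the scatter), although neither group carries a ring. A ring is also not required to reach the level of the 4-methylpiperazin-1-yl group, as the step between those two compounds is a 1.8-fold lower number from compound 1 to compound 4 (0.26 log units; within the scatter), so no order can be placed on them. The step from the azetidin-1-yl group to methoxy is an at least 5.8-fold lower number from compound 2 to compound 4 (0.76 log units; beyond the scatter), and its size is only a floor, as the value of compound 2 is a limit and not a number: the limit of > 5000 nM in this assay, at which 1 of the 4 values shown sits.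

What sets methoxy apart from chloro cannot be told from these compounds, and the one hydrogen-bond acceptor that enters with methoxy is a count from the structures, not a demonstrated cause. Going by these compounds, it remains open whether a longer chain such as ethoxy, a hydroxyl group or a simple primary amine at this position would behave like methoxy, and whether the same exchange would have a similar effect on any other core.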